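This account rests on a few compounds, and the source may have more. Where it says the series, first, only, none or still open, it means among the compounds named here.

In a functional assay on A2780 cells (Homo sapiens) for antiproliferative activity, read by fluorescence, with a stated time of 72 h (a higher number here means a weaker inhibitor, a lower number a stronger inhibitor), compound 2 (`CN1CCC(C(=O)N2Cc3c(NC(=O)c4ccc5ccccc5c4)n[nH]c3C2(C)C)CC1`) gives 270 nM. Going by the values given here, compound 3 (`CC(C)(C)C(=O)N1Cc2c(NC(=O)c3ccc(F)cc3)n[nH]c2C1(C)C`) gives 270 nM, so these two stand level and share the lowest number of the three measured so far. Compound 1 (`CN1CCC(C(=O)N2Cc3c(NC(=O)NCc4ccccc4)n[nH]c3C2(C)C)CC1`) gives 2680 nM.

The unmeasured compound 4 (`CN1CCC(C(=O)N2Cc3c(NC(=O)c4cccs4)n[nH]c3C2(C)C)CC1`) keeps the rest of compound 2 but carries thiophen-2-yl in place of naphthalen-2-yl on a carbonyl carbon. Among the compounds with values here, only one measured step touches this place: a 9.9-fold lower number from compound 1 to compound 2 (1.00 log units; beyond the scatter), with naphthalen-2-yl in place of benzylamino. Within the data shown here, no measured compound carries thiophen-2-yl, and compound 3 differs from compound 2 in more than one place, so it offers only a loose guide.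

With a 9.9-fold lower number from compound 1 to compound 2 (1.00 log units; beyond the scatter) as the main guide, a modest rise in the number is expected in this assay, smaller than that step. The estimated change is a 2.2-fold higher number from compound 2 to compound 4 (0.35 log units; beyond the scatter). For compound 4 the expected value is 600 nM, with an estimated range from 200 nM to 1800 nM.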

Compound 4, half-maximal inhibitory concentration: 30 nM
Compound 4: middle estimate off by 20-fold (1.30 log units), on the high side, outside the stated range (below it).
By their numbers in this assay, from the lowest: compound 4; then compounds 2 and 3 (each within the scatter of the next); then compound 1.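

Thiophen-2-yl in place of naphthalen-2-yl on a carbonyl carbon gives a 9.0-fold lower number from compound 2 to compound 4 (0.95 log units; beyond the scatter) in this assay and shows that the larger aromatic group is not the best of those tried at this position. Going by these compounds alone, compound 2 had so far offered only a gain over benzylamino, whereas the smaller ring goes much further, with an 89-fold lower number from compound 1 to compound 4 (1.95 log units; beyond the scatter) for the same place. Nothing available here explains why the number falls so sharply with this change.

Within the data shown here, with only one five-membered ring, these compounds cannot separate the effect of ring size from that of the sulfur atom. Furan-2-yl, which has oxygen in place of that sulfur, or thiophen-3-yl, joined to the carbonyl through a different ring carbon, would be needed to tell how specific this gain is.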